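Swapping the aromatic group on an amide nitrogen

This account rests on a few compounds, and the source may have more. Where it says the series, first, only, none or still open, it means among the compounds named here.

In a functional assay on K562 cells (Homo sapiens) for inhibition, read by MTT assay, with a stated time of 48 h (a higher number here means a weaker inhibitor, a lower number a stronger inhibitor), compound 1 `CC(C)(C)OC(=O)N1C[C@@H](n2cc(-c3ccc4nc(N)sc4n3)nn2)C[C@H]1C(=O)Nc1ccc(Cl)c(C(F)(F)F)c1` gives 10900 nM. Compound 2 `Nc1nc2ccc(-c3cn([C@@H]4CN[C@H](C(=O)Nc5ccc(Cl)c(C(F)(F)F)c5)C4)nn3)nc2s1`, with hydrogen in place of tert-butoxycarbonyl on an amine nitrogen in a ring, gives 26200 nM, the higher and therefore weaker of the two numbers.

Compound 3 `Nc1nc2ccc(-c3cn([C@@H]4CN[C@H](C(=O)Nc5ccc(F)c(F)c5)C4)nn3)nc2s1` keeps the core of compound 2 but has 3,4-difluorophenyl in place of 4-chloro-3-(trifluoromethyl)phenyl on an amide-type nitrogen.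

Going by the values given here, only one measured step is available, a 2.4-fold higher number from compound 1 to compound 2 (0.38 log units; beyond the scatter). It is modest and lies elsewhere in the molecule, so it offers a rough guide to size but none to direction. Among the compounds with values here, no measured pair tests a change on the amide-type nitrogen. Within the data shown here, a change no larger than that step is therefore expected in this assay, probably within the scatter, with a slight and unproven lean towards a higher number. The expected step is a 1.2-fold higher number from compound 2 to compound 3 (0.09 log units; within the scatter). Compound 3 is estimated at 32000 nM, with an expected range from 12000 nM to 80000 nM.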

Compound 3, half-maximal inhibitory concentration: 33200 nM
Compound 3: middle estimate off by 1.0-fold (0.02 log units), on the low side; low and high end bracket the measured number.
By their numbers in this assay, from the lowest: compound 1; then compounds 2 and 3 (each within the scatter of the next).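

Going by these compounds alone, this is the first measured change on the amide-type nitrogen, and in this assay it amounts to a 1.3-fold higher number from compound 2 to compound 3 (0.10 log units; within the scatter). Putting 3,4-difluorophenyl in place of 4-chloro-3-(trifluoromethyl)phenyl takes the group from 11 heavy atoms to 8 and removes the chlorine, yet compound 2 and compound 3 cannot be told apart in this assay, so this particular swap leaves the cell result unchanged within the usual scatter. No measurement among the data shown accounts for this outcome.

Both groups are halogen-bearing phenyl rings, so the compounds shown leave open how the position responds to something quite different, such as an unsubstituted phenyl, a pyridine ring, or a phenyl carrying a methoxy group or an amine. They also leave open whether the same swap would give a matching result with tert-butoxycarbonyl still on the amine nitrogen in the ring, as in compound 1.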